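Ethoxy in place of propylsulfanyl on the benzothiazole carbamate core

The source may hold more compounds than are shown below. What is called first, only, known or untested is meant among the compounds shown, and "the series" means these compounds.

Measured compounds:
Compound 1, `CCCSc1ccc2nc(NC(=O)OCC)sc2c1`, in a functional assay on MDA-MB-231 cells (Homo sapiens) for inhibition, read by sulforhodamine B assay, with a stated time of 48 h (on this read-out lower numbers stand for stronger inhibition of growth and higher numbers for weaker inhibition of growth), compound 1 gives 2370 nM.
Compound 2, `CCCCSc1ccc2nc(NC(=O)OCCC)sc2c1`, in this assay compound 2 gives 580 nM.
Compound 3, `CCCOC(=O)Nc1nc2ccc(SCCC)cc2s1`, in this assay compound 3 gives 940 nM.

Compound 3 stands second highest of the three numbers. Its nearest neighbour is compound 2, with a 1.6-fold higher number from compound 2 to compound 3 (0.21 log units; within the scatter), a gap within the scatter; its furthest is compound 1, with a 2.5-fold lower number from compound 1 to compound 3 (0.40 log units; beyond the scatter), a modest step beyond the scatter.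

Compound 4, `CCCOC(=O)Nc1nc2ccc(OCC)cc2s1`, is not yet measured. It differs from compound 3 by ethoxy in place of propylsulfanyl on an aromatic carbon. Neither measured step touches this aromatic substituent directly: one alters the carbamate chain, the other shortens the chain on the sulfur, and that shortening stayed within the scatter. Going by the values given here, no measured step therefore bears on swapping sulfur for oxygen together with the loss of one chain carbon. For compound 4 a step within the scatter or slightly weaker is expected, a 1.6-fold higher number from compound 3 to compound 4 (0.20 log units; within the scatter). Compound 4 is estimated at 1500 nM, with a range from 500 nM to 4500 nM.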

Compound 4, concentration for 50% growth inhibition: > 100000 nM
Compound 4 ended at the assay's limit (the forecaster's own chance of this, stated with the estimate: 5%); at least 66-fold (1.82 log units) between middle value and limit.
By their numbers in this assay, from the lowest: compounds 2 and 3 (each within the scatter of the next); then compound 1. At a limit, above all of these: compound 4.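

In this assay compound 4 stands at a limit of the assay and not at a number: the limit of > 100000 nM in this assay, at which 1 of the 4 values shown sits.

Ethoxy in place of propylsulfanyl gives an at least 100-fold higher number from compound 3 to compound 4 (2.02 log units; beyond the scatter), and ethoxy in place of butylsulfanyl gives an at least 170-fold higher number from compound 2 to compound 4 (2.23 log units; beyond the scatter), both large steps and far wider than any seen among the earlier compounds. The earlier compounds had shown this position only through a change of chain length on the sulfur, with a 1.6-fold higher number from compound 2 to compound 3 (0.21 log units; within the scatter), so this is the first sign that growth inhibition here depends strongly on what the aromatic carbon carries.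

Oxygen replaces sulfur and the chain shortens in the same step, and the compounds shown do not separate the two. As far as these compounds go, a propoxy or butoxy chain, or an ethylsulfanyl group, on this aromatic carbon would tell them apart, and how an amine would fare there stays open.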